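Swapping a Triazole for an Isothiazole on the Distal Ring

The compounds below may be only part of what the source reports. "The series", "measured", "known", "first", "only" and "open" are said of these compounds alone.

For the measured compounds named here, compound 2 `CCC(C)(C)Cc1c[nH]c(CCc2ccc(-n3cncn3)cc2)n1` holds the higher of the two numbers measured so far. Going by the values given here, in a functional assay on HEK293 cells for agonist activity at Bombesin receptor subtype-3 (Homo sapiens), read by luminescence and calcium flux, with a stated time of 10 min (on this read-out lower numbers stand for an effect already at smaller amounts and higher numbers for an effect only at larger amounts of compound), compound 2 gives 570 nM, while its only neighbour, compound 1 `CCC(C)(C)Cc1c[nH]c(CCc2ccc(-c3cccc(N)n3)cc2)n1`, gives 37 nM. Among the compounds with values here, the single measured step, a 15-fold higher number from compound 1 to compound 2 (1.19 log units; beyond the scatter), shows that the ring hanging off the six-membered carbon ring has a strong influence on this assay. Compound 3 `CCC(C)(C)Cc1c[nH]c(CCc2ccc(-c3ccns3)cc2)n1` has not been measured; it differs from compound 2 in one place: 1,2-thiazol-5-yl in place of 1H-1,2,4-triazol-1-yl on an aromatic carbon. The incoming ring is joined through a ring carbon and carries fewer nitrogen atoms than the triazole it replaces, which makes it more like the aminopyridine of compound 1 than the triazole of compound 2. Because a 15-fold higher number from compound 1 to compound 2 (1.19 log units; beyond the scatter) was large, a sizeable move is plausible here too, and the direction is expected to be toward a lower number, though not all the way back to compound 1, since the incoming ring also lacks the amino group of compound 1. For compound 3, the expected step is a 3.2-fold lower number from compound 2 to compound 3 (0.50 log units; beyond the scatter). Compound 3 is therefore estimated at 180 nM, within a range of 45 nM to 700 nM.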

Compound 3, half-maximal effective concentration: 63 nM
Compound 3: middle estimate off by 2.9-fold (0.46 log units), on the high side, and the stated range covers the measured number.
By their numbers in this assay, from the lowest: compounds 1 and 3 (each within the scatter of the next); then compound 2.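

At this position, para to a large group, the outcome depends strongly on which five-membered aromatic ring is attached: the two rings have the same number of heavy atoms, yet this assay gives a 9.0-fold lower number from compound 2 to compound 3 (0.96 log units; beyond the scatter). The step to the aminopyridine ring, a 1.7-fold higher number from compound 1 to compound 3 (0.23 log units; within the scatter), lies within the scatter, so compound 1 and compound 3 cannot be told apart here. The earlier pair could have suggested that the amino group of compound 1 was needed for a low number, but compound 3 shows that a ring without that group can give a result in the same range.

The change from compound 2 to compound 3 alters the ring's joining atom, its nitrogen count and the presence of sulfur all at once, so a 1,2,4-triazole joined through a ring carbon or a plain phenyl ring would be needed to separate these differences. No independent measurement is available to explain why this ring change shifts the result.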